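A few compounds are considered here, and "the series" means these few. Any claim that something is new, unique, unknown or untested is made for them only; others in the source may bear on it.

Compound 1 `COc1cc2c(Nc3ccc(C#N)cc3)ncnc2cc1OCCCN(C)C` carries a dimethylamino group on a saturated chain carbon, three bonds along the chain from an oxygen on an aromatic ring; in a functional assay on SH-SY5Y cells (Homo sapiens) for antiproliferative activity, read by MTT assay, with a stated time of 72 h (a lower number here means a stronger inhibitor, a higher number a weaker inhibitor), compound 1 gives 34900 nM. Compound 2 `COc1cc2c(Nc3ccc(C#N)cc3)ncnc2cc1OCCCN1CCCC1` has pyrrolidin-1-yl there instead, and in this assay compound 2 gives 8080 nM. That single measured step, a 4.3-fold lower number from compound 1 to compound 2 (0.64 log units; beyond the scatter), leaves compound 2 with the lowest number of the two. Compound 3 `COc1cc2c(Nc3ccc(C#N)cc3)ncnc2cc1OCCCN1CCc2ccccc2C1` changes the same group again: 1,2,3,4-tetrahydroisoquinolin-2-yl in place of pyrrolidin-1-yl on a saturated chain carbon, three bonds along the chain from an oxygen on an aromatic ring. For the measured compounds named here, only the step from compound 1 to compound 2 bears on this change, and there a ring amine in place of an open one went with a lower number. The same direction is expected here, as a modest step of about a 2.0-fold lower number from compound 2 to compound 3 (0.31 log units; beyond the scatter). Compound 3 is therefore expected to give 4000 nM in this assay, within a range from 1000 nM to 15000 nM.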

Compound 3, half-maximal inhibitory concentration: > 100000 nM
Compound 3 gave a limit, no number (the forecaster's own chance of this, stated with the estimate: 5%); middle value at least 25-fold (1.39 log units) away from the limit.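

Compound 3 shows that a ring on the amine does not by itself go with a lower number at this position: in this assay, the change to 1,2,3,4-tetrahydroisoquinolin-2-yl brings an at least 12-fold higher number from compound 2 to compound 3 (1.09 log units; beyond the scatter). Even against the open dimethylamino group, the same ring goes the wrong way, with an at least 2.8-fold higher number from compound 1 to compound 3 (0.45 log units; beyond the scatter). The reading for compound 3 is a limit of the assay and not a number: the limit of > 100000 nM in this assay, at which 1 of the 3 values shown sits.

Across these three compounds the number falls and then rises as the amine changes, so the gain seen with pyrrolidin-1-yl does not extend to every ring amine. Still open, going by these compounds, is how piperidin-1-yl, a six-membered ring amine without the fused aromatic ring, would behave on the same chain, which would help separate the effect of ring size from that of the added aromatic ring.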